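The source may hold more compounds than are shown below. What is called first, only, known or untested is meant among the compounds shown, and "the series" means these compounds.

Three analogues sharing one core have been measured in a functional assay on SK-MEL-2 cells (Homo sapiens) for cytotoxicity, read by sulforhodamine B assay, with a stated time of 2 days, tested at 100 uM; a higher number here means more inhibition at the concentration tested (going by the name of the read-out), a lower number less inhibition. Compound 1 `COc1cccc(-c2nc3c(-c4ccc(Cl)cc4)n[nH]c3c(=O)n2NC(=O)c2ccncc2)c1` gives 39.6%, compound 2 `O=C(Nn1c(-c2cccc([N+](=O)[O-])c2)nc2c(-c3ccc(F)cc3)n[nH]c2c1=O)c1cccnc1` gives 24.5%, and compound 3 `COc1cccc(-c2nc3c(-c4ccc(C5CCNCC5)cc4)n[nH]c3c(=O)n2NC(=O)c2ccncc2)c1` gives 23.4%. Compound 2 therefore stands below compound 1 by a margin beyond the scatter, while its number and that of compound 3 lie within the scatter of each other.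

The next compound, compound 4 `O=C(Nn1c(-c2cccc([N+](=O)[O-])c2)nc2c(CCc3ccccc3)n[nH]c2c1=O)c1cccnc1`, differs from compound 2 in one place: phenethyl in place of 4-fluorophenyl on an aromatic carbon.

Among the measured compounds shown here, only one measured step touches the same position of the core. There, a number 16.2 percentage points lower from compound 1 to compound 3 (beyond the scatter). That step, however, swaps a small substituent on the aryl ring for a larger one and keeps the aryl ring, whereas the present change replaces the whole 4-fluorophenyl by phenethyl, so it offers little direct guidance. For the measured compounds named here, with no closer precedent, a step of at most modest size is expected, and the direction is uncertain.

On that basis compound 4 is estimated to give 21% in this assay, with a plausible range from 6% to 38%. The expected change is a number 3.5 percentage points lower from compound 2 to compound 4 (within the scatter).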

Compound 4, a percentage reported as inhibition, at one concentration (the size of the read-out at that concentration, not a potency): 28.5%
Beside the measured number, compound 4's estimate is 7.5 percentage points below it; the range from low to high includes it.
By their numbers in this assay, from the lowest: compounds 3, 2 and 4 (each within the scatter of the next); then compound 1.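

Putting phenethyl in place of 4-fluorophenyl on this aromatic carbon gives a number 4 percentage points higher from compound 2 to compound 4 (within the scatter) in this assay, so the number stays within the scatter even though the 4-fluorophenyl itself leaves. Among the compounds shown here, the only earlier step at this position, from compound 1 to compound 3, kept the aryl ring and changed only its substituent, so this is the first sign that the group as a whole can be exchanged here without a shift beyond the scatter, at least with the 3-nitrophenyl and pyridin-3-yl groups of compound 2 in place. No measurement shown offers an explanation for this result.

Going by these compounds, whether the same exchange would behave alike on the core of compound 1 remains open. So does the outcome with a group carrying no aromatic ring at this position, such as cyclohexyl or an aminoethyl chain.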